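Pyrazole ureas: methoxy to hydroxy on the chlorophenyl arm

A few compounds are considered here, and "the series" means these few. Any claim that something is new, unique, unknown or untested is made for them only; others in the source may bear on it.

Compound 1 `COc1cc(-c2nn(-c3cccc(NC(=O)Nc4cc(C(F)(F)F)cc(C(F)(F)F)c4)c3)cc2-c2ccncc2)ccc1Cl` carries a 4-chloro-3-methoxyphenyl group on the shared core and a bis(trifluoromethyl)phenyl urea. In a functional assay on SK-MEL-28 cells (Homo sapiens) for inhibition, read by sulforhodamine B assay, with a stated time of 48 h (a lower number here means a stronger inhibitor of growth, a higher number a weaker inhibitor of growth), compound 1 gives 851 nM. Compound 2 `O=C(Nc1cccc(-n2cc(-c3ccncc3)c(-c3ccc(Cl)c(O)c3)n2)c1)Nc1cc(C(F)(F)F)cc(C(F)(F)F)c1` differs from it only by hydrogen in place of methyl on an oxygen on an aromatic ring; in this assay compound 2 gives 796 nM, and the step is a 1.1-fold lower number from compound 1 to compound 2 (0.03 log units; within the scatter). Compound 3 `COc1cc(-c2nn(-c3cccc(NC(=O)Nc4ccc(Cl)c(C(F)(F)F)c4)c3)cc2-c2ccncc2)ccc1Cl` keeps the 4-chloro-3-methoxyphenyl group but carries a 4-chloro-3-(trifluoromethyl)phenyl urea instead; in this assay compound 3 gives 1200 nM. The difference between the core of compound 3 and the core of compound 1 is not broken down here. The three measured values all lie within the scatter of one another, so no ordering among compounds 1, 2 and 3 is claimed.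

Compound 4 `O=C(Nc1cccc(-n2cc(-c3ccncc3)c(-c3ccc(Cl)c(O)c3)n2)c1)Nc1ccc(Cl)c(C(F)(F)F)c1` is not yet measured. It stands to compound 3 as compound 2 stands to compound 1: hydrogen in place of methyl on an oxygen on an aromatic ring. The place is the same word for word in both pairs, so this is the same change made on a different urea partner.

The expected step in this assay is a 1.1-fold lower number from compound 3 to compound 4 (0.04 log units; within the scatter), set beside the measured 1.1-fold lower number from compound 1 to compound 2 (0.03 log units; within the scatter); the expectation rests on that single earlier step, which the data show as flat. For compound 4 the expected value in this assay is 1100 nM, with a range from 550 nM to 2200 nM to cover the usual scatter. Going by the values given here, only one prior instance of the change supports this, so the range is kept wide.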

Compound 4, concentration for 50% growth inhibition: 978 nM
Compound 4: middle estimate off by 1.1-fold (0.05 log units), on the high side, and the stated range covers the measured number.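

Methoxy to hydroxy, carried from the bis(trifluoromethyl)phenyl urea to the 4-chloro-3-(trifluoromethyl)phenyl urea, gives in this assay a 1.2-fold lower number from compound 3 to compound 4 (0.09 log units; within the scatter), so the change again leaves the growth-inhibition number inside the scatter. Set side by side, the two steps do not differ, and on these two urea partners the change carries over as a flat step: the same change on two cores in this assay, a 1.1-fold lower number (0.03 log units; within the scatter) from compound 1 to compound 2 and a 1.2-fold lower number (0.09 log units; within the scatter) from compound 3 to compound 4, 1.1-fold (0.06 log units) apart, within the scatter of two such steps. This shows only that the free hydroxy and the methoxy cannot be told apart in this one cell read-out on two closely related pairs; it does not show that the change would stay flat on other urea partners, and a flat step gives no information on why the number stays put or on how these compounds behave in any other test.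

Still open, from the compounds shown here alone, is whether the flat result holds when the methyl on the oxygen gives way to a longer chain such as ethyl or propyl, or when an amine or a carboxylic acid takes the place of the methoxy. Also open, going by these compounds, is whether the same step stays flat on a urea partner carrying a nitrile or a simple methyl in place of trifluoromethyl.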